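The source may report more compounds than this note shows. Statements on the series, on what has been measured and on what is new or still open speak of the compounds shown alone.

In an ADME assay on the whole organism (plasma) for pharmacokinetics, with Rattus norvegicus as the target, with a stated time of 6 h, at a dose of 10 mg/kg by the oral route (on this read-out lower numbers stand for lower exposure and higher numbers for higher exposure at the dose given), compound 1 `CC1(COc2c(N3CCN(S(=O)(=O)Cc4ccc(N)cc4)CC3)cnn(-c3cccc(Cl)c3)c2=O)CC1` gives 8100 ng.h/mL and compound 2 `CC1(COc2c(N3CCN(S(=O)(=O)Cc4ccc(N)c(F)c4)CC3)cnn(-c3cc(F)cc(F)c3)c2=O)CC1` gives 890 ng.h/mL. Compound 2 thus holds the lower of the two numbers, beyond the scatter. Among the compounds with values here, these two compounds differ in more than one place, so no measured pair isolates the next change. Compound 3 `Cc1cc(CS(=O)(=O)N2CCN(c3cnn(-c4cc(F)cc(F)c4)c(=O)c3OCC3(C)CC3)CC2)ccc1N` carries methyl in place of fluoro on an aromatic carbon, ortho to an amino group: methyl in place of fluoro on an aromatic carbon. Within the data shown here, with no measured step for this change, no shift beyond the scatter is expected in this assay. The expected step is a 1.2-fold higher number from compound 2 to compound 3 (0.09 log units; within the scatter). For compound 3 the estimated value is 1100 ng.h/mL, with a range of 350 ng.h/mL to 3500 ng.h/mL.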

Compound 3, area under the concentration-time curve: 14500 ng.h/mL
For compound 3 the middle estimate is 13-fold (1.12 log units) below the measured one; measured number above the stated range.
By their numbers in this assay, from the lowest: compound 2; then compounds 1 and 3 (each within the scatter of the next).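

In this assay, within the data shown here, methyl in place of fluoro gives a 16-fold higher number from compound 2 to compound 3 (1.21 log units; beyond the scatter) as the first single-place change. The position ortho to an amino group on the 4-amino-3-fluorobenzyl group therefore has a large effect on exposure, even though the swap involves one heavy atom and no change in counted donors, acceptors or net charge. Nothing available here accounts for this step.

Going by these compounds, whether the gain is specific to methyl remains open, and an ethyl or methoxy group at this position would test that. On these data alone, whether the step carries over to other aryl groups on the core also remains open.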